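A few compounds are considered here, and "the series" means these few. Any claim that something is new, unique, unknown or untested is made for them only; others in the source may bear on it.

Among the measured compounds shown here, in a functional assay on A549 cells (Homo sapiens) for antiproliferative activity, read by MTT assay, with a stated time of 48 h (a lower number here means a stronger inhibitor, a higher number a weaker inhibitor), two compounds have numbers so far. Compound 1 (`CC(C)CCC1(O)C(=O)Nc2ccc(Nc3ccc(F)cc3)cc21`) gives 5700 nM and compound 2 (`CCCCC1(O)C(=O)Nc2ccc(Nc3ccc(C(F)(F)F)cc3)cc21`) gives 2300 nM as the lower of the two, a gap that lies beyond the usual scatter. Compound 2 therefore stands as the stronger inhibitor of this pair. Compound 3 (`CC(C)CCC1(O)C(=O)Nc2ccc(Nc3ccc(C(F)(F)F)cc3)cc21`) has yet to be measured. It departs from compound 2 by methyl in place of hydrogen on a saturated chain carbon bound to two saturated chain carbons and so carries methyl in place of hydrogen on a saturated chain carbon bound to two saturated chain carbons, which turns butyl into isopentyl. For the measured compounds named here, no measured pair shows this change on its own. Starting from compound 2 at 2300 nM as the reference, no step beyond the scatter is expected in this assay. The estimated change is a 1.1-fold higher number from compound 2 to compound 3 (0.04 log units; within the scatter) and has no firm direction. Compound 3 is expected near 2500 nM (estimated range 1100 nM to 5500 nM).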

Compound 3, half-maximal inhibitory concentration: 4200 nM
Compound 3: the middle estimate sits 1.7-fold (0.23 log units) below what was measured; low and high end bracket the measured number.
By their numbers in this assay, from the lowest: compounds 2, 3 and 1 (each within the scatter of the next, the first and the last beyond it).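

In this assay, each of the two places can now be read on its own. Methyl in place of hydrogen on a saturated chain carbon bound to two saturated chain carbons, which turns butyl into isopentyl, gives a 1.8-fold higher number from compound 2 to compound 3 (0.26 log units; within the scatter), and trifluoromethyl in place of fluoro on an aromatic carbon gives a 1.4-fold lower number from compound 1 to compound 3 (0.13 log units; within the scatter), so neither single change moves the number beyond the scatter. Nothing given here accounts for either step.

The compounds shown compare only butyl with isopentyl on the chain and only fluoro with trifluoromethyl on the aromatic carbon. From the compounds shown here alone, what a shorter chain such as ethyl, a chain ending in an amine, or a nitrile in place of trifluoromethyl would give remains open.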